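This account rests on a few compounds, and the source may have more. Where it says the series, first, only, none or still open, it means among the compounds named here.

All three measured compounds share one core and differ only in the group on an aromatic carbon. Compound 1 `Cc1cc(C#N)cc(C)c1Oc1nc(Nc2ccc(C#N)cc2)ncc1-c1ccccc1` gives 31800 nM in an ADME assay on MT4 cells (Homo sapiens) for cytotoxicity, read by MTT assay, with a stated time of 5 days; a lower number here means that less compound is tolerated, a higher number that more compound is tolerated. Compound 2 `Cc1cc(C#N)cc(C)c1Oc1nc(Nc2ccc(C#N)cc2)ncc1-c1ccc(-c2ccccc2)cc1` reaches only a limit of this assay, > 253000 nM. Compound 3 `Cc1cc(C#N)cc(C)c1Oc1nc(Nc2ccc(C#N)cc2)ncc1-c1cccnc1` gives 13500 nM in this assay, the lowest of the two plain numbers, so the least compound is tolerated there. The change to compound 4 `Cc1cc(C#N)cc(C)c1Oc1nc(Nc2ccc(C#N)cc2)ncc1-c1ccc(C(F)(F)F)cc1` is 4-(trifluoromethyl)phenyl in place of pyridin-3-yl on an aromatic carbon. The step of a 2.4-fold lower number from compound 1 to compound 3 (0.37 log units; beyond the scatter) runs the other way, and an at least 7.9-fold higher number from compound 1 to compound 2 (0.90 log units; beyond the scatter) shows that putting phenyl in place of hydrogen raised the number. A rise is therefore expected for compound 4, a 4.4-fold higher number from compound 3 to compound 4 (0.65 log units; beyond the scatter), giving an estimate of 60000 nM, between 20000 nM and 200000 nM.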

Compound 4, half-maximal cytotoxic concentration: 35000 nM
The estimate for compound 4 lay 1.7-fold (0.23 log units) above the measured number; the measured number falls inside the stated range.
By their numbers in this assay, from the lowest: compound 3; then compounds 1 and 4 (each within the scatter of the next). At a limit, above all of these: compound 2.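

In this assay, 4-(trifluoromethyl)phenyl in place of pyridin-3-yl gives a 2.6-fold higher number from compound 3 to compound 4 (0.41 log units; beyond the scatter), so this ring swap moves the number back up. Trifluoromethyl in place of hydrogen gives a 1.1-fold higher number from compound 1 to compound 4 (0.04 log units; within the scatter), so these two compounds cannot be told apart. Trifluoromethyl in place of phenyl gives an at least 7.2-fold lower number from compound 2 to compound 4 (0.85 log units; beyond the scatter), so the group carried on that ring can matter, although compound 2 gives only a limit: the limit of > 253000 nM in this assay, at which 1 of the 4 values shown sits.

From the compounds shown here alone, how an amine or a carboxylic acid on that ring would read in this assay stays open. So does whether other nitrogen-containing rings would match pyridin-3-yl.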